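A few compounds are considered here, and "the series" means these few. Any claim that something is new, unique, unknown or untested is made for them only; others in the source may bear on it.

Measured in a functional assay on A549 cells (Homo sapiens) for cytotoxicity, read by resazurin assay, with a stated time of 72 h; a lower number here means a stronger inhibitor, a higher number a weaker inhibitor:
Compound 1 `N#Cc1cc(-c2ccccc2)n(-c2ccncc2)c1N`: 10700 nM
Compound 2 `N#Cc1cc(-c2ccccc2)n(-c2cccc(Br)c2)c1N`: 13000 nM

Among the compounds with values here, with only two values in hand, compound 2 cannot be told apart from its one neighbour: the step is a 1.2-fold higher number from compound 1 to compound 2 (0.08 log units; within the scatter). Compound 3 `N#Cc1cc(-c2ccccc2)n(-c2ccc(Br)cc2)c1N` has the same atoms as compound 2, joined differently: 4-bromophenyl in place of 3-bromophenyl on an aromatic nitrogen. The change lies on the aromatic nitrogen of the shared core. Within the data shown here, no measured pair tests a shift of the bromine itself, so the evidence is thin. Among the measured compounds shown here, the only guide is the swap at that same nitrogen, 3-bromophenyl in place of pyridin-4-yl, which gave a 1.2-fold higher number from compound 1 to compound 2 (0.08 log units; within the scatter). A change at this place has so far left the number in this assay within the scatter, so none beyond the scatter is expected here, and the estimate is a 1.1-fold lower number from compound 2 to compound 3 (0.03 log units; within the scatter). Compound 3 is estimated at 12000 nM, with an expected range of 5500 nM to 26000 nM.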

Compound 3, half-maximal inhibitory concentration: 4600 nM
The estimate for compound 3 lay 2.6-fold (0.42 log units) above the measured number, outside the stated range (below it).
By their numbers in this assay, from the lowest: compound 3; then compounds 1 and 2 (each within the scatter of the next).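

Moving the bromine alone, with 4-bromophenyl in place of 3-bromophenyl on the aromatic nitrogen, gives a 2.8-fold lower number from compound 2 to compound 3 (0.45 log units; beyond the scatter) in this assay, so this position can respond even though the earlier swap there stayed within the scatter. The two groups have the same atoms and the same counts, and differ only in where the bromine sits; against the pyridin-4-yl group as well, 4-bromophenyl gives a 2.3-fold lower number from compound 1 to compound 3 (0.37 log units; beyond the scatter), a step of similar modest size. Nothing measured here explains why the place of the bromine matters.

From the compounds shown here alone, whether the lower number is special to bromine stays open, since 4-chlorophenyl or 4-methoxyphenyl would test that. The phenyl, amino and cyano groups on the shared core are the same in all three compounds, so what a carboxylic acid or a longer chain would do at those places is also unknown.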